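The compounds below may be only part of what the source reports. "The series", "measured", "known", "first", "only" and "open" are said of these compounds alone.

Measured so far in a functional assay on HCT-116 cells (Homo sapiens) for antiproliferative activity, read by MTT assay, with a stated time of 48 h; a higher number here means a weaker inhibitor, a lower number a stronger inhibitor:
compound 1 (`CC(CCO)n1cnc2c(Cl)ncnc21`) gives > 50000 nM
compound 2 (`CCC(CCO)n1cnc2c(Cl)ncnc21`) gives > 50000 nM
compound 3 (`CCCCCCC(CCO)n1cnc2c(Cl)ncnc21`) gives 11900 nM

Compound 1 gives > 50000 nM, which is a limit of the assay and not a number. Compound 2, at > 50000 nM, also sits at a limit. For the measured compounds named here, compound 3, at 11900 nM, is the only one of the three with an actual number, so it is the sole firm point of comparison in this assay.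

Compound 4 (`CCCCCCCC(CCO)n1cnc2c(Cl)ncnc21`) extends the chain of compound 3, and the difference is methyl in place of hydrogen on a saturated chain carbon, seven bonds along the chain from an aromatic nitrogen.

Going by the values given here, two measured steps bear on this change. The first is an at least 4.2-fold lower number from compound 1 to compound 3 (0.62 log units; beyond the scatter), and the second is an at least 4.2-fold lower number from compound 2 to compound 3 (0.62 log units; beyond the scatter). Both point towards a lower number with a longer chain, but both add a larger group than the single methyl considered here. The remaining step, a step that the two limits leave unreadable from compound 1 to compound 2, offers no size to build on. A small further fall in the number is therefore expected in this assay, possibly one that stays within the usual scatter.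

The estimated step is a 1.5-fold lower number from compound 3 to compound 4 (0.17 log units; within the scatter).

Compound 4 is expected at 8000 nM, with an estimated range of 3500 nM to 20000 nM.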

Compound 4, half-maximal inhibitory concentration: 4160 nM
Compound 4: middle estimate off by 1.9-fold (0.28 log units), on the high side, and the stated range covers the measured number.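

In this assay, for the compounds shown here, methyl in place of hydrogen, seven bonds along the chain from an aromatic nitrogen, gives a 2.9-fold lower number from compound 3 to compound 4 (0.46 log units; beyond the scatter), so a change as small as this one still moves the number beyond the usual scatter, which the larger additions in the earlier steps could not show. Going by these compounds alone, compound 4 also supplies the first large steps in this short series, an at least 12-fold lower number from compound 2 to compound 4 (1.07 log units; beyond the scatter) and an at least 12-fold lower number from compound 1 to compound 4 (1.07 log units; beyond the scatter), both read from a compound that sits at a limit of the assay. The pentyl change can now be read twice, though only as a comparison of two lower bounds: the same change on two cores in this assay, an at least 4.2-fold lower number (0.62 log units; beyond the scatter) from compound 1 to compound 3 and an at least 12-fold lower number (1.07 log units; beyond the scatter) from compound 2 to compound 4; the limit leaves it open whether they differ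

Going by these compounds, whether a longer chain would lower the number further, level off or reverse the fall stays open, as does the effect of an amine or a carboxylic acid in place of this methyl. The shorter chains also give no firm starting point for the trend, so where the number begins to fall remains unknown: the limit of > 50000 nM in this assay, at which 2 of the 4 values shown sit.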